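Removing the Methoxy Group From Compound 3

This account rests on a few compounds, and the source may have more. Where it says the series, first, only, none or still open, it means among the compounds named here.

In a functional assay on PC-3 cells (Homo sapiens) for cytotoxicity, read by MTT assay, with a stated time of 72 h (on this read-out higher numbers stand for weaker inhibition and lower numbers for stronger inhibition), compound 3 `COc1ccc(-n2ccc(=O)c(C(=O)Nc3ccc(Oc4ccnc5c4ccn5C)c(F)c3)n2)cc1` sits at a limit of the assay, giving > 60000 nM. Two neighbours set the scene. Compound 1 `COc1ccc(-n2ccc(=O)c(C(=O)Nc3ccc(Oc4ccnc5c4ccn5C)cc3)n2)cc1` also gives only a limit, > 60000 nM. Compound 2 `Cn1ccc2c(Oc3ccc(NC(=O)c4nn(-c5ccccc5)ccc4=O)cc3)ccnc21` gives a number, 58200 nM. Most values in this small set cluster at the limit of > 60000 nM in this assay, at which 2 of the 3 values shown sit.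

Compound 4 `Cn1ccc2c(Oc3ccc(NC(=O)c4nn(-c5ccccc5)ccc4=O)cc3F)ccnc21` differs from compound 3 in one place: hydrogen in place of methoxy on an aromatic carbon. The same change has been measured once already, where it produced an at least 1.0-fold lower number from compound 1 to compound 2 (0.01 log units; that floor lies within the scatter), a step that stays inside the usual scatter. A different change, fluoro in place of hydrogen, gave a step that the two limits leave unreadable from compound 1 to compound 3, so it adds nothing readable. Nothing measured here points to a large move in either direction when the methoxy is taken away.

Compound 4 is therefore expected to remain close to where compound 3 stands, with a step that the limit leaves unreadable from compound 3 to compound 4 estimated as no step beyond the scatter. The estimate for compound 4 is 65000 nM, in a range from 40000 nM to 120000 nM, with a real chance that only a limit is reported again.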

Compound 4, half-maximal inhibitory concentration: > 60000 nM
Compound 4: no number, only a limit (the forecaster's own chance of this, stated with the estimate: 60%); the middle value is on the limit's open side.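

In this assay, taking the methoxy away from compound 3 does not bring out a readable number: compound 4 also stays at a limit of the assay, so the steps that join two limits cannot be read. The fluoro change can now also be followed on the compounds without the methoxy, where the result is an at least 1.0-fold higher number from compound 2 to compound 4 (0.01 log units; that floor lies within the scatter). With fluoro present, the change from 4-methoxyphenyl to phenyl therefore leaves the compound at the same limit, and the set gathers there even more: the limit of > 60000 nM in this assay, at which 3 of the 4 values shown sit.

From the compounds shown here alone, whether the methoxy or the fluoro has any real effect on this read-out stays open, as values at a limit hide how weak each compound truly is. Also open, going by these compounds, is what another group in the place of the methoxy would do, such as an amine or a carboxylic acid.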